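Replacing the (2-hydroxyhexyl)carbonyl group of compound 2

The source may hold more compounds than are shown below. What is called first, only, known or untested is meant among the compounds shown, and "the series" means these compounds.

Going by the values given here, in a functional assay on DU-145 cells (Homo sapiens) for cytotoxicity, read by MTT assay (a higher number here means a weaker inhibitor, a lower number a stronger inhibitor), compound 2 `CCCCC(O)CC(=O)O[C@H](CC=C(C)C)C1=CC(=O)c2c(O)ccc(O)c2C1=O` gives 45300 nM, the higher of the two numbers so far, and compound 1 `COC(C)CO[C@H](CC=C(C)C)C1=CC(=O)c2c(O)ccc(O)c2C1=O` gives 16600 nM. The next compound, compound 3 `COCCO[C@H](CC=C(C)C)C1=CC(=O)c2c(O)ccc(O)c2C1=O`, carries 2-methoxyethyl in place of (2-hydroxyhexyl)carbonyl on an oxygen on a saturated carbon. Among the compounds with values here, only one measured step bears on this change: a 2.7-fold higher number from compound 1 to compound 2 (0.44 log units; beyond the scatter), which is modest and beyond the scatter, with (2-hydroxyhexyl)carbonyl in place of 2-methoxypropyl at the same place. The change to compound 3 runs the opposite way, so a step of similar size towards a lower number, meaning a stronger inhibitor, is expected in this assay. A single step is thin support for this. The expected step is a 2.5-fold lower number from compound 2 to compound 3 (0.40 log units; beyond the scatter). For compound 3 the estimated value is 18000 nM, with a range of 9000 nM to 36000 nM.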

Compound 3, half-maximal inhibitory concentration: 43200 nM
For compound 3 the middle estimate is 2.4-fold (0.38 log units) below the measured one, outside the stated range (above it).
By their numbers in this assay, from the lowest: compound 1; then compounds 3 and 2 (each within the scatter of the next).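

In this assay the exchange of (2-hydroxyhexyl)carbonyl for 2-methoxyethyl on this oxygen gives a 1.0-fold lower number from compound 2 to compound 3 (0.02 log units; within the scatter) and so leaves the read-out unmoved, despite the large difference between the two groups. The new comparison at this position is the much smaller change, hydrogen in place of methyl on the saturated chain carbon, with a 2.6-fold higher number from compound 1 to compound 3 (0.42 log units; beyond the scatter) as the step, so that the methyl of 2-methoxypropyl separates compound 1 from compound 3 while the whole-group exchange does not separate compound 2 from compound 3. Nothing available accounts for either step.

Going by these compounds, whether this methyl step holds on other chains remains open, as a single pair supports it. Also open, on these data alone, is how an ethyl branch, a longer alkyl chain, an amine or a carboxylic acid at this oxygen would compare with compound 1 in this assay.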